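The source may hold more compounds than are shown below. What is called first, only, known or untested is meant among the compounds shown, and "the series" means these compounds.

Measured so far:
- compound 1 `CN1CCCN(c2cnc(NCc3c(F)ccc4c3CCO4)n3cnnc23)C1=O`: 153000 nM
- compound 2 `O=C1CCCN1c1cnc(NCc2c(F)ccc3c2CCO3)n2cnnc12`: < 1600 nM

In a physicochemical assay for solubility, at pH 7.4 (a higher number here means a more soluble compound, a lower number a less soluble compound), compound 1 gives 153000 nM. For compound 2 the assay returns only a limit, < 1600 nM, so its position is known only as a ceiling (the limit of < 1600 nM in this assay, at which 1 of the 2 values shown sits). Going by the values given here, the single measured step, an at least 95-fold lower number from compound 1 to compound 2 (1.98 log units; beyond the scatter), is large and runs downward, and it is the only comparison available for the core shared by both compounds.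

Compound 3 `O=C1CCCCN1c1cnc(NCc2c(F)ccc3c2CCO3)n2cnnc12` is not yet measured. It differs from compound 2 by 2-oxopiperidin-1-yl in place of 2-oxopyrrolidin-1-yl on an aromatic carbon. The measured step concerned a different exchange, a six-membered ring with two hetero atoms giving way to a five-membered ring with one; the change here enlarges the lactam ring by one carbon while keeping one hetero atom, so the measured step does not carry over directly. Among the compounds with values here, with no measured step of this kind, the expectation is for a small effect at most, in either direction, possibly within the scatter, and a fair chance that this assay again reports only a limit.

Compound 3 is therefore estimated at 3000 nM, within 800 nM to 15000 nM. The expected step of an at least 1.8-fold higher number from compound 2 to compound 3 (0.27 log units; that floor lies within the scatter) is small and uncertain in sign.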

Compound 3, solubility: 351000 nM
For compound 3 the middle estimate is 120-fold (2.07 log units) below the measured one, and the stated range ends below it.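

In this assay, going by these compounds alone, the size of the lactam ring at this position on the aromatic carbon matters far more than the single earlier step could show: 2-oxopiperidin-1-yl in place of 2-oxopyrrolidin-1-yl gives an at least 210-fold higher number from compound 2 to compound 3 (2.34 log units; beyond the scatter). That step is only a floor, since compound 2 carries a limit of the assay and not a number: the limit of < 1600 nM in this assay, at which 1 of the 3 values shown sits. The other new comparison is a 2.3-fold higher number from compound 1 to compound 3 (0.36 log units; beyond the scatter), a modest step, so the low reading of compound 2 does not simply follow the loss of the second hetero atom in the ring, which compound 3 lacks as well, and among these three compounds the five-membered lactam is the one that stands apart.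

The three groups shown are all cyclic and all carry a carbonyl, so it remains open whether a seven-membered lactam, an open-chain amide or a plain amine at this position would read like compound 2 or like compound 3. The compounds also do not say why a single added ring carbon goes with a step of this size.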